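Swapping 3-bromophenyl for 4-ethoxyphenyl on a shared core

The compounds below may be only part of what the source reports. "The series", "measured", "known", "first", "only" and "open" are said of these compounds alone.

Of the compounds shown here, three have been measured in a functional assay on A549 cells (Homo sapiens) for antiproliferative activity, read by MTT assay, with a stated time of 48 h; a higher number here means a weaker inhibitor, a lower number a stronger inhibitor. Compound 1 `CCCC(C)Oc1ccc(C(=O)/C=C/c2c(/C=C/c3ccc(OC)cc3)cc(OC)cc2OC)cc1` gives 9.4 ug/mL, compound 2 `COc1ccc(/C=C/c2cc(OC)cc(OC)c2/C=C/C(=O)c2cccc(Br)c2)cc1` gives 8.1 ug/mL and compound 3 `COc1ccc(/C=C/c2cc(OC)cc(OC)c2/C=C/C(=O)c2ccc(F)cc2)cc1` gives 6.6 ug/mL. Compound 2 therefore stands within the scatter of both other compounds.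

Compound 4 `CCOc1ccc(C(=O)/C=C/c2c(/C=C/c3ccc(OC)cc3)cc(OC)cc2OC)cc1` has 4-ethoxyphenyl in place of 3-bromophenyl on a carbonyl carbon. The nearest measured comparison is compound 1, which holds 4-(1-methylbutoxy)phenyl on that same carbonyl carbon. Its step to the 3-bromophenyl compound is a 1.2-fold lower number from compound 1 to compound 2 (0.06 log units; within the scatter). The two other measured exchanges at this place are a 1.4-fold lower number from compound 1 to compound 3 (0.15 log units; within the scatter) and a 1.2-fold lower number from compound 2 to compound 3 (0.09 log units; within the scatter). None of the three steps exceeds the scatter, so no change beyond the scatter is expected in this assay for the new exchange. The estimated step is a 1.0-fold higher number from compound 2 to compound 4 (0.02 log units; within the scatter). For compound 4 the estimated value is 8.5 ug/mL, with an expected range from 5 ug/mL to 14 ug/mL.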

Compound 4, half-maximal inhibitory concentration: 7.5 ug/mL
Compound 4: middle estimate off by 1.1-fold (0.05 log units), on the high side; low and high end bracket the measured number.
By their numbers in this assay, from the lowest: compounds 3, 4, 2 and 1 (each within the scatter of the next).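

In this assay, 4-ethoxyphenyl on the carbonyl carbon stays within the scatter of all three other groups held there, as seen from 3-bromophenyl (a 1.1-fold lower number from compound 2 to compound 4 (0.03 log units; within the scatter)), from the fluoro compound (a 1.1-fold higher number from compound 3 to compound 4 (0.06 log units; within the scatter)) and from the longer ether (a 1.3-fold lower number from compound 1 to compound 4 (0.10 log units; within the scatter)). For the compounds shown here, until now this place had held only one alkoxy-bearing ring, and the second shows that ethoxy and 1-methylbutoxy cannot be told apart here, while 4-ethoxyphenyl also brings a hydrogen-bond acceptor that 3-bromophenyl lacks without a step beyond the scatter. No supporting measurement bears on why these groups read alike.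

Whether any group on this carbonyl carbon can give a step beyond the scatter remains open, since the compounds shown include no ring carrying an amine or a carboxylic acid. They also leave open what changes elsewhere on the shared core would do.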